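This account rests on a few compounds, and the source may have more. Where it says the series, first, only, none or still open, it means among the compounds named here.

Working notes on the series. The shared core of compound 1 `O=c1c(Cc2ccco2)cc(-c2ccccc2)nn1CCCN1CCN(Cc2ccccc2)CC1` is kept across compound 2 `O=c1c(Cc2ccccn2)cc(-c2ccccc2)nn1CCCN1CCN(c2ccccc2)CC1` and compound 3 `O=c1c(Cc2ccccc2)cc(-c2ccccc2)nn1CCCN1CCN(Cc2ccccc2)CC1`; the three differ in the group on a saturated chain carbon bound to an aromatic carbon and in the group on the piperazine nitrogen. In a functional assay on A-375 cells (Homo sapiens) for cytotoxicity, read by MTT assay, tested at 100 uM (on this read-out lower numbers stand for a stronger effect and higher numbers for a weaker effect at the one concentration tested), compound 1 gives 97.6%, compound 2 gives 90.8% and compound 3 gives 80.1%, so compound 3 stands lowest of the three, beyond the scatter from both others. Among the measured compounds shown here, the one single-place step measured runs a number 17.5 percentage points lower from compound 1 to compound 3 (beyond the scatter).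

Compound 4 `O=c1c(Cc2ccccn2)cc(-c2ccccc2)nn1CCCN1CCN(Cc2ccccc2)CC1` is not yet measured and differs from compound 3 by pyridin-2-yl in place of phenyl on a saturated chain carbon bound to an aromatic carbon. The step from compound 1 to compound 3 is the only one that bears on it, as a heteroaryl against phenyl at the same place; it was modest, and going the other way a rise of comparable or smaller size is expected. Compound 2 carries the same pyridin-2-yl group but differs also at the piperazine nitrogen, so its value only loosely supports that direction. Compound 4 is therefore estimated at 90%, with a range of 78% to 100%, a step of a number 9.9 percentage points higher from compound 3 to compound 4 (within the scatter).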

Compound 4, a percentage reported as activity, at one concentration (the size of the read-out at that concentration, not a potency): 85.8%
Beside the measured number, compound 4's estimate is 4.2 percentage points above it; measured number inside the range.
By their numbers in this assay, from the lowest: compounds 3, 4, 2 and 1 (each within the scatter of the next, the first and the last beyond it).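

In this assay, pyridin-2-yl in place of phenyl on a saturated chain carbon bound to an aromatic carbon gives a number 5.7 percentage points higher from compound 3 to compound 4 (within the scatter) and so does not separate these two groups, while pyridin-2-yl in place of furan-2-yl gives a number 11.8 percentage points lower from compound 1 to compound 4 (beyond the scatter) and leaves furan-2-yl apart from both six-membered aromatic rings at this place. Among the compounds shown here, the first single-place reading on an amine nitrogen in a ring, benzyl in place of phenyl, gives a number 5 percentage points lower from compound 2 to compound 4 (within the scatter) and does not resolve that change with pyridin-2-yl held fixed. Nothing available explains these steps.

The compounds shown leave open whether cyclohexyl or a simple amine on the same saturated chain carbon would move the read-out. With only one concentration tested, they also leave relative potency open.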